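The source may hold more compounds than are shown below. What is called first, only, known or untested is meant among the compounds shown, and "the series" means these compounds.

Measured compounds:
Compound 1, `CC1(C)[C@H]2CC[C@]1(C)N(Cc1cn(-c3cccc(Br)c3)nn1)C(=O)C2`: 90 nM
Compound 2, `CC1(C)[C@H]2CC[C@]1(C)N(Cc1cn(-c3ccccc3F)nn1)C(=O)C2`: 240 nM

In a functional assay on A549 cells (Homo sapiens) for inhibition, read by MTT assay, with a stated time of 24 h (on this read-out lower numbers stand for stronger inhibition and higher numbers for weaker inhibition), compound 2 gives the higher of the two numbers recorded so far; its nearest neighbour is compound 1, and the step of a 2.7-fold higher number from compound 1 to compound 2 (0.43 log units; beyond the scatter) lies beyond the scatter. Compound 3, `CC1(C)[C@H]2CC[C@]1(C)N(Cc1cn(-c3cccc(C#N)c3)nn1)C(=O)C2`, has not yet been measured. It differs from compound 2 in one place: 3-cyanophenyl in place of 2-fluorophenyl on an aromatic nitrogen. Going by the values given here, only one measured step bears on this change, a 2.7-fold higher number from compound 1 to compound 2 (0.43 log units; beyond the scatter), which went from a 3-bromophenyl to the 2-fluorophenyl of compound 2. Among the compounds with values here, the 3-cyanophenyl of compound 3 shares its naming pattern with the 3-bromophenyl of compound 1 rather than with the 2-fluorophenyl, so a modest move back toward the number of compound 1 is expected, while the nitrile itself has no precedent among the measured compounds. Compound 3 is therefore estimated at 160 nM, within 60 nM to 450 nM, which means an expected step of a 1.5-fold lower number from compound 2 to compound 3 (0.18 log units; within the scatter).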

Compound 3, half-maximal inhibitory concentration: 440 nM
For compound 3 the middle estimate is 2.8-fold (0.44 log units) below the measured one; the measured number falls inside the stated range.
By their numbers in this assay, from the lowest: compound 1; then compounds 2 and 3 (each within the scatter of the next).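

In this assay, the shared numbering of the 3-bromophenyl and 3-cyanophenyl groups does not bring their numbers together: the change of bromo to cyano gives a 4.9-fold higher number from compound 1 to compound 3 (0.69 log units; beyond the scatter), so at this position the identity of the group counts, not only where it stands on the phenyl ring. Set against the 2-fluorophenyl, the 3-cyanophenyl gives a 1.8-fold higher number from compound 2 to compound 3 (0.26 log units; within the scatter), and this assay does not separate these two groups. The data offer no explanation for the gap between bromo and cyano.

Going by these compounds, whether a 3-chlorophenyl or a 3-methoxyphenyl would fall nearer compound 1 or compound 3 remains open. Also open, on these data alone, is what the place of a group contributes on its own, since compound 1 and compound 2 differ in both the halogen and its place on the ring.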